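A few compounds are considered here, and "the series" means these few. Any claim that something is new, unique, unknown or untested is made for them only; others in the source may bear on it.

In a functional assay on PC-3 cells (Homo sapiens) for inhibition, with a stated time of 72 h (a lower number here means a stronger inhibitor, a higher number a weaker inhibitor), compound 1 `COc1ccc(NC(=O)Nc2nc(Sc3c[nH]c4ccccc34)cc(N3CCN(c4ccccn4)CC3)n2)cc1` gives 33400 nM. Compound 3 `O=C(Nc1ccccc1)Nc1nc(Sc2c[nH]c3ccccc23)cc(N2CCN(Cc3ccccc3)CC2)n1` gives 42500 nM in this assay. In this assay compound 2 `Cc1ccc(C)c(NC(=O)Nc2nc(Sc3c[nH]c4ccccc34)cc(N3CCCCC3)n2)c1` gives > 50000 nM, which is a limit of the assay and not a number. Compound 2 alone sits at the limit of > 50000 nM in this assay, at which 1 of the 3 values shown sits. Compound 4 `O=C(Nc1ccc(Cl)cc1)Nc1nc(Sc2c[nH]c3ccccc23)cc(N2CCCCC2)n1` has not yet been measured in this assay; it differs from compound 2 by 4-chlorophenyl in place of 2,5-dimethylphenyl on an amide-type nitrogen. Within the data shown here, with compound 2 known only as a limit, no measured step between a pair of compounds sets a scale for this change; the aryl ureas of compound 1 and compound 3 both fall in the weak range. Compound 4 is expected to stay weak, at 40000 nM in this assay, between 15000 nM and 100000 nM. The step from compound 2 to compound 4 is expected to be an at least 1.2-fold lower number from compound 2 to compound 4 (0.09 log units; that floor lies within the scatter), with a fair chance that compound 4 also returns only a limit.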

Compound 4, half-maximal inhibitory concentration: 42500 nM
The estimate for compound 4 lay 1.1-fold (0.03 log units) below the measured number; measured number inside the range.
By their numbers in this assay, from the lowest: compounds 1, 3 and 4 (each within the scatter of the next). At a limit, above all of these: compound 2.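

In this assay compound 4 gives a measurable number, 42500 nM, so a 4-chlorophenyl on this amide-type nitrogen keeps the compound within the assay's measurable range. Replacing 2,5-dimethylphenyl with 4-chlorophenyl gives an at least 1.1-fold lower number from compound 2 to compound 4 (0.07 log units; that floor lies within the scatter), so the true size of the change remains unfixed. Compound 2 remains a limit of the assay and not a number: the limit of > 50000 nM in this assay, at which 1 of the 4 values shown sits.

On these data alone, whether any change at this position can move the number beyond the scatter remains open. Also open, as far as these compounds go, is how a carboxylic acid or a dimethylamino group on the aryl ring would read in this assay.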